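The compounds below may be only part of what the source reports. "The series", "measured", "known", "first", "only" and "open" are said of these compounds alone.

Measured so far, in a functional assay on HT-29 cells (Homo sapiens) for cytotoxicity, read by MTT assay, with a stated time of 72 h; a higher number here means a weaker inhibitor, a lower number a stronger inhibitor:
compound 1 `C#CCOc1cccc(/C=C/C(=O)Nc2cc(C(=O)c3cc(OC)c(OC)c(OC)c3)ccc2OC)c1` — 7400 nM
compound 2 `COc1ccc(C(=O)c2cc(OC)c(OC)c(OC)c2)cc1NC(=O)/C=C/c1ccc(F)cc1` — 1800 nM
compound 3 `COc1ccc(C(=O)c2cc(OC)c(OC)c(OC)c2)cc1NC(=O)/C=C/c1ccc(C(F)(F)F)cc1` — 1600 nM

Compound 3 gives the lowest of the three numbers, yet its separation from compound 2 is within the scatter, so neither can be called the stronger of the two; only the gap to compound 1 is real, as seen in a 4.6-fold lower number from compound 1 to compound 3 (0.67 log units; beyond the scatter) and in a 4.1-fold lower number from compound 1 to compound 2 (0.61 log units; beyond the scatter).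

Compound 4 `COc1ccc(C(=O)c2cc(OC)c(OC)c(OC)c2)cc1NC(=O)/C=C/c1ccc([N+](=O)[O-])cc1` is the next case. It differs from compound 3 in one place: nitro in place of trifluoromethyl on an aromatic carbon, sitting on an aromatic carbon of a six-membered carbon ring, para to a large group. Within the data shown here, the one measured step that touches this position is a 1.1-fold lower number from compound 2 to compound 3 (0.05 log units; within the scatter), where exchanging one group for another on that same carbon left the number unchanged within the scatter. Among the measured compounds shown here, no measured compound carries a nitro group, so the data give no direct footing for it. On the step already seen, the expected change from compound 3 to compound 4 in this assay is small, a 1.1-fold lower number from compound 3 to compound 4 (0.03 log units; within the scatter), with no clear direction. Compound 4 is therefore estimated at 1500 nM, within a range of 500 nM to 5000 nM.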

Compound 4, half-maximal inhibitory concentration: 5100 nM
Compound 4: the middle estimate sits 3.4-fold (0.53 log units) below what was measured; the whole stated range lies below it.
By their numbers in this assay, from the lowest: compounds 3 and 2 (each within the scatter of the next); then compounds 4 and 1 (each within the scatter of the next).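

In this assay, this position proves sensitive to the group it carries: nitro brings a 3.2-fold higher number from compound 3 to compound 4 (0.50 log units; beyond the scatter) and a 2.8-fold higher number from compound 2 to compound 4 (0.45 log units; beyond the scatter), both beyond the scatter, whereas the exchange of fluoro for trifluoromethyl had left the number unchanged within the scatter. The gap that separated compounds 2 and 3 from compound 1 does not extend to the nitro compound, as a 1.5-fold lower number from compound 1 to compound 4 (0.16 log units; within the scatter) lies within the scatter, so compound 4 cannot be told apart from the 3-(propargyloxy)phenyl compound. No measurement is available that explains why nitro departs from the other two groups.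

From the compounds shown here alone, with only fluoro, trifluoromethyl and nitro on this carbon, it remains open whether the shift is peculiar to nitro. A nitrile, an amine or a carboxylic acid at the same place could show whether it recurs.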